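Can 3,4-Dichlorophenyl Bring Back Antiproliferative Activity?

The source may hold more compounds than are shown below. What is called first, only, known or untested is meant among the compounds shown, and "the series" means these compounds.

Values measured in a functional assay on MCF cells (Homo sapiens) for antiproliferative activity, with a stated time of 72 h; on this read-out lower numbers stand for stronger inhibition and higher numbers for weaker inhibition:
Compound 1 `OC[C@H]1O[C@@H](n2cnc3c(NCc4cccc(F)c4)ncnc32)[C@H](O)[C@@H]1O`: 15300 nM
Compound 2 `Cc1ccc(CNc2ncnc3c2ncn3[C@@H]2O[C@H](CO)[C@@H](O)[C@H]2O)cc1`: > 166000 nM

Compound 2 stands at > 166000 nM, and this is a limit of the assay, not a number. Compound 3 `OC[C@H]1O[C@@H](n2cnc3c(NCc4ccc(Cl)c(Cl)c4)ncnc32)[C@H](O)[C@@H]1O` has not yet been measured. It carries 3,4-dichlorophenyl in place of the 4-methylphenyl of compound 2, on a saturated chain carbon bound to a nitrogen on an aromatic ring (3,4-dichlorophenyl in place of 4-methylphenyl on a saturated chain carbon bound to a nitrogen on an aromatic ring).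

A single measured step bears on this change. Putting 4-methylphenyl in place of 3-fluorophenyl at that same place gave an at least 10-fold higher number from compound 1 to compound 2 (1.03 log units; beyond the scatter), a large step beyond the scatter. Compound 3 also lacks the 4-methylphenyl group, and so the expectation leans on compound 1 at 15300 nM. A move to a lower number in this assay is therefore expected, though it may not reach the level of compound 1. The expected change is an at least 3.6-fold lower number from compound 2 to compound 3 (0.56 log units; beyond the scatter), a loose figure since it starts from a limit. For compound 3 the estimate is 45000 nM, with an expected range of 12000 nM to 150000 nM.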

Compound 3, half-maximal inhibitory concentration: 88800 nM
The estimate for compound 3 lay 2.0-fold (0.30 log units) below the measured number; measured number inside the range.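

In this assay, 3,4-dichlorophenyl in place of 4-methylphenyl on the saturated chain carbon gives an at least 1.8-fold lower number from compound 2 to compound 3 (0.27 log units; that floor lies within the scatter), so this change returns a measurable number where compound 2 gave none. Against 3-fluorophenyl at the same place, however, 3,4-dichlorophenyl gives a 5.8-fold higher number from compound 1 to compound 3 (0.76 log units; beyond the scatter), so the recovery does not reach the level of compound 1, and the identity of the aryl group still matters at this place. The true size of the first step remains unfixed, and its floor cannot be told from the scatter, because compound 2 has only a limit and not a number: the limit of > 166000 nM in this assay, at which 1 of the 3 values shown sits.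

The groups 3-fluorophenyl, 4-methylphenyl and 3,4-dichlorophenyl differ in both the kind and the number of groups they carry on the ring, so the compounds shown cannot separate one of these differences from the other. They also leave open how a phenyl ring carrying an amine or a carboxylic acid, or a longer chain between the ring and the nitrogen, would read in this assay.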